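A chloro step on an inactive anilide

This account rests on a few compounds, and the source may have more. Where it says the series, first, only, none or still open, it means among the compounds named here.

Compound 1 `O=C(O)CCCCC(CCSC(=O)c1ccccc1)SC(=O)c1ccccc1` gives 89.8%
Compound 2 `O=C(CCCCC(S)CCS)Nc1ccc(Br)cn1` gives 59.2%
Compound 3 `O=C(CCCCC(CCSC(=O)c1ccccc1)SC(=O)c1ccccc1)Nc1ccccc1` gives "not active" (no number reported)

All three results come from a functional assay on KB cells (Homo sapiens) for inhibition, read by MTT assay, with a stated time of 24 h, tested at 100 ug/mL (a higher number here means more inhibition of growth at the concentration tested, a lower number less inhibition of growth), and there compound 3 stands without a number, recorded as "not active" (no number reported) and so offering no figure to measure from. Compound 4 `O=C(CCCCC(CCSC(=O)c1ccccc1)SC(=O)c1ccccc1)Nc1cccc(Cl)c1` keeps compound 3 intact apart from one edit. That edit is chloro in place of hydrogen on an aromatic carbon and it sits on an aromatic carbon, meta to a large group, turning phenyl into 3-chlorophenyl. Among the measured compounds shown here, no measured pair shows this change, so its size is uncertain. A modest gain in this assay is expected, though another result without a number would be no surprise. Compound 4 is estimated at 25% with values between 0% and 60% as its expected range.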

Compound 4, percent growth inhibition at one concentration: "not active" (no number reported)
Compound 4 has no reported number here; the estimate stays without a comparison.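

In this assay, among the compounds shown here, compound 3 gives "not active" (no number reported) and compound 4 gives "not active" (no number reported) with no number for either, so no step between them can be read. Going by these compounds, whether changing phenyl to 3-chlorophenyl alters growth inhibition at all stays open. No evidence here bears on this result.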